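Moving the oxygen: from compound 3 to compound 4

This account rests on a few compounds, and the source may have more. Where it says the series, first, only, none or still open, it means among the compounds named here.

In a physicochemical assay for solubility, in phosphate buffer, at pH 7.4 (on this read-out lower numbers stand for lower solubility and higher numbers for higher solubility), compound 1 (`OCC1CCN(c2nccnc2OC2CN(c3nc4ccccc4s3)C2)CC1`) gives 31000 nM and compound 2 (`OCC1CCN(c2cccnc2OC2CN(c3ccc4ccccc4n3)C2)CC1`) gives 189000 nM while compound 3 (`OCCC1CCN(c2nccnc2OC2CN(c3ccc4ccccc4n3)C2)CC1`) gives 84000 nM and so stands second highest of the three, with both of its gaps beyond the scatter. Compound 4 (`COCC1CCN(c2nccnc2OC2CN(c3ccc4ccccc4n3)C2)CC1`) holds the same atoms as compound 3, joined differently: methoxy in place of hydroxymethyl on a saturated chain carbon bound to a saturated ring carbon. Cut one bond further out, the change reads 2-hydroxyethyl to methoxymethyl. For the measured compounds named here, no measured pair shows this change, so the expectation rests on the structural change alone. A small fall is expected, estimated as a 1.5-fold lower number from compound 3 to compound 4 (0.18 log units; within the scatter) and within the scatter. Compound 4 is estimated at 55000 nM with 20000 nM to 130000 nM as the expected range.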

Compound 4, solubility: 53000 nM
Compound 4: the middle estimate sits 1.0-fold (0.02 log units) above what was measured; the measured number falls inside the stated range.
By their numbers in this assay, from the lowest: compounds 1, 4 and 3 (each within the scatter of the next, the first and the last beyond it); then compound 2.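

In this assay, for the compounds shown here, the change from 2-hydroxyethyl to methoxymethyl on the 4-substituted piperidine gives a 1.6-fold lower number from compound 3 to compound 4 (0.20 log units; within the scatter) and is the first step read at this position. Removing the hydrogen-bond donor of the hydroxyl therefore leaves the read-out within the scatter for this pair. Nothing at hand bears on the reason for this result.

As far as these compounds go, whether the same exchange stays within the scatter on another core remains open. So does how an amine or a carboxylic acid at this place would read in this assay.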